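Working notes: changing the group on the ring nitrogen

The compounds below may be only part of what the source reports. "The series", "measured", "known", "first", "only" and "open" are said of these compounds alone.

Values in a functional assay on HepG2 cells (Homo sapiens) for antiproliferative activity, read by MTT assay, with a stated time of 48 h; on this read-out lower numbers stand for stronger inhibition and higher numbers for weaker inhibition:
compound 1 `S=c1oc(-c2ccc3c(c2)OCCO3)nn1CN1CCN(C(c2ccccc2)c2ccccc2)CC1` gives 9120 nM
compound 2 `Fc1ccccc1N1CCN(Cn2nc(-c3ccc4c(c3)OCCO4)oc2=S)CC1` gives > 50000 nM (a limit)
compound 3 `S=c1oc(-c2ccc3c(c2)OCCO3)nn1CN1CCN(c2ccc(Cl)cc2)CC1` gives > 50000 nM (a limit)

Compound 3 stands only at a limit, > 50000 nM, and has no numerical value. Within the data shown here, the series so far is dominated by the limit of > 50000 nM in this assay, at which 2 of the 3 values shown sit. Compound 4 `COc1cccc(N2CCN(Cn3nc(-c4ccc5c(c4)OCCO5)oc3=S)CC2)c1` carries 3-methoxyphenyl in place of 4-chlorophenyl on an amine nitrogen in a ring. Among the measured compounds shown here, the only measured step at this place is a step that the two limits leave unreadable from compound 2 to compound 3, so its size offers no guide. No step beyond the scatter is expected in this assay, and a reading at or near the limit is likely. The estimated change is an at least 1.1-fold lower number from compound 3 to compound 4 (0.04 log units; that floor lies within the scatter). For compound 4 the expected value is 45000 nM, with an estimated range of 18000 nM to 90000 nM.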

Compound 4, half-maximal inhibitory concentration: 21400 nM
Beside the measured number, compound 4's estimate is 2.1-fold (0.32 log units) above it; measured number inside the range.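

In this assay, a phenyl group on this amine nitrogen can now give a readable number: 3-methoxyphenyl brings an at least 2.3-fold lower number from compound 3 to compound 4 (0.36 log units; beyond the scatter) and an at least 2.3-fold lower number from compound 2 to compound 4 (0.36 log units; beyond the scatter). Both steps start from a limit, so each is only a floor, and the step between the two compounds at the limit cannot be read. The limit still dominates the series: the limit of > 50000 nM in this assay, at which 2 of the 4 values shown sit.

The compounds shown do not separate the methoxy group itself from its place on the phenyl ring. An unsubstituted phenyl, or a phenyl bearing an amine or a carboxylic acid, lies outside them.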